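Triazole thioethers: chloro in place of methoxy

The source may hold more compounds than are shown below. What is called first, only, known or untested is meant among the compounds shown, and "the series" means these compounds.

Measured so far:
compound 1 `Brc1ccc(CSc2nnc(-c3ccncc3)n2-c2ccccc2)cc1` — 12600 nM
compound 2 `O=[N+]([O-])c1cccc(CSc2nnc(-c3ccncc3)n2-c2ccccc2)c1` — 18300 nM
compound 3 `COc1ccc(/C=N/NC(=O)CSc2nnc(-c3ccncc3)n2-c2ccccc2)cc1` — 23700 nM

In a functional assay on MCF7 cells (Homo sapiens) for inhibition, read by MTT assay, with a stated time of 48 h (a higher number here means a weaker inhibitor, a lower number a stronger inhibitor), compound 3 gives 23700 nM, the highest of the three numbers, though compound 2 and compound 1 both lie within the scatter of it. Compound 4 `O=C(CSc1nnc(-c2ccncc2)n1-c1ccccc1)N/N=C/c1ccc(Cl)cc1` differs from compound 3 by chloro in place of methoxy on an aromatic carbon. For the measured compounds named here, the only measured step, a 1.5-fold higher number from compound 1 to compound 2 (0.16 log units; within the scatter), concerns the aromatic ring on the other side of the shared core and stayed within the scatter. Going by the values given here, no step on the ring that carries the methoxy has been measured, so nothing points to a change beyond the scatter. The expected step is a 1.2-fold lower number from compound 3 to compound 4 (0.07 log units; within the scatter). Compound 4 is estimated at 20000 nM, with a range from 8000 nM to 50000 nM.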

Compound 4, half-maximal inhibitory concentration: 9930 nM
Compound 4: middle estimate off by 2.0-fold (0.30 log units), on the high side; the measured number falls inside the stated range.
By their numbers in this assay, from the lowest: compounds 4, 1, 2 and 3 (each within the scatter of the next, the first and the last beyond it).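

In this assay, for the compounds shown here, the step from 4-methoxyphenyl to 4-chlorophenyl gives a 2.4-fold lower number from compound 3 to compound 4 (0.38 log units; beyond the scatter) and is the first step to pass beyond the scatter, though only modestly. Going by these compounds alone, the earlier step, a 1.5-fold higher number from compound 1 to compound 2 (0.16 log units; within the scatter), concerned a different part of the series and stayed within it, so this aromatic carbon is the one place so far where a single change shifts the number. Nothing at hand bears on why the number moved.

A single pair cannot show whether the shift is particular to chloro. Fluoro, an amine or a carboxylic acid on the same aromatic carbon would test how far it extends.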